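Phenyl in place of methoxy: the step to compound 4

The source may hold more compounds than are shown below. What is called first, only, known or untested is meant among the compounds shown, and "the series" means these compounds.

Compound 1, `CC(=N)Nc1cccc(C(=O)NNC(=O)CC(CC(=O)O)c2ccc(-c3ccccc3)cc2)c1`, in a physicochemical assay for lipophilicity; a lower number here means a more polar compound, a higher number a more lipophilic compound: 3.11
Compound 2, `O=C(O)CC(CC(=O)NNC(=O)CCCCNc1ccccn1)c1ccc(Cl)cc1`, in this assay: 2.63
Compound 3, `COc1ccc(C(CC(=O)O)CC(=O)NNC(=O)CCCCNc2ccccn2)cc1`, in this assay: 1.94

Compound 3 has the lowest of the three numbers in this assay. Going by the values given here, its nearest neighbour is compound 2, and the only one-place step among the measured compounds is a number 0.69 log units lower from compound 2 to compound 3 (beyond the scatter), a modest step beyond the scatter. Compound 1 stands further away and differs from compound 3 in more than one place, so its number tells only what a biphenyl-bearing compound with another core can show.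

Compound 4, `O=C(O)CC(CC(=O)NNC(=O)CCCCNc1ccccn1)c1ccc(-c2ccccc2)cc1`, differs from compound 3 in one place: phenyl in place of methoxy on an aromatic carbon. Among the compounds with values here, no measured pair shows exactly this change. The step from compound 2 to compound 3 shows how large a swap of one small group for another on this aromatic carbon can be; replacing methoxy with a whole phenyl ring is a larger change, and compound 1 with its biphenyl gives the highest value seen. Compound 4 is therefore expected to move upward by a number 1.46 log units higher from compound 3 to compound 4 (beyond the scatter), clearly beyond the scatter. The estimate for compound 4 in this assay is 3.4, with a range from 2.7 to 4.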

Compound 4, partition coefficient: 3.74
Beside the measured number, compound 4's estimate is 0.34 log units below it; the measured number falls inside the stated range.
By their numbers in this assay, from the lowest: compound 3; then compound 2; then compound 1; then compound 4.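

Going by these compounds alone, at this aromatic carbon, the earlier compounds showed only a swap between two small groups, whereas a whole phenyl ring gives a much larger move in this assay: a number 1.80 log units higher from compound 3 to compound 4 (beyond the scatter) and a number 1.11 log units higher from compound 2 to compound 4 (beyond the scatter). With these steps, the three groups at this position form a clear order, with methoxy lowest, chloro in the middle and phenyl highest, and each gap lies beyond the scatter. The phenyl-bearing ring also turns out not to fix the number alone, since exchanging only the group on the carbonyl carbon, with that ring kept in place, gives a number 0.63 log units higher from compound 1 to compound 4 (beyond the scatter).

Three groups at one position cannot show whether a cyclohexyl ring, a longer chain or an amine on the same aromatic carbon would follow this order, or whether the size of the new group matters more than its aromatic ring. Nothing in the data on hand explains why the steps at this position are as large as they are.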